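Ester size on the shared core: isopropyl to methyl

This account rests on a few compounds, and the source may have more. Where it says the series, first, only, none or still open, it means among the compounds named here.

In an assay on isolated protein (strain albino) for antagonist activity at Voltage-dependent L-type calcium channel subunit alpha-1C (Cavia porcellus) (a higher number here means a weaker inhibitor, a lower number a stronger inhibitor), compound 1 `CSc1ncc(C2C(C(=O)OC(C)C)=C(C)NC(C)=C2C(=O)OC(C)C)n1Nc1ccccc1` gives 2.16 nM, the lower of the two numbers in hand; compound 2 `CSc1ncc(C2C(C(=O)OCCc3ccccc3)=C(C)NC(C)=C2C(=O)OCCc2ccccc2)n1Nc1ccccc1` gives 2.79 nM, which lies within the scatter of compound 1. Compound 3 `COC(=O)C1=C(C)NC(C)=C(C(=O)OC(C)C)C1c1cnc(SC)n1Nc1ccccc1` has not been measured; it differs from compound 1 by methyl in place of isopropyl on an oxygen next to a carbonyl group. Going by the values given here, no measured pair shows this change. The expected step is a 1.4-fold higher number from compound 1 to compound 3 (0.14 log units; within the scatter), no larger than the usual scatter and with no settled direction. Compound 3 is estimated at 3 nM, with a range from 1 nM to 10 nM.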

Compound 3, half-maximal inhibitory concentration: 6.35 nM
Beside the measured number, compound 3's estimate is 2.1-fold (0.33 log units) below it; the measured number falls inside the stated range.
By their numbers in this assay, from the lowest: compounds 1 and 2 (each within the scatter of the next); then compound 3.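

In this assay, going by these compounds alone, the single change of isopropyl to methyl gives a 2.9-fold higher number from compound 1 to compound 3 (0.47 log units; beyond the scatter) and so provides the first step read at one place, showing that this ester position is sensitive to the change, though only modestly. Compound 3 keeps its other isopropyl ester, so the step describes the loss of one isopropyl group only. Nothing measured here gives a reason for the step. Still open, as far as these compounds go, is whether an ethyl group or a longer chain at this ester stays close to compound 1 or to compound 3. Also open, from the compounds shown here alone, is whether methyl in place of the second isopropyl adds a further step.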